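The source may report more compounds than this note shows. Statements on the series, on what has been measured and on what is new or still open speak of the compounds shown alone.

Measured so far in an ADME assay on MT4 cells (Homo sapiens) for cytotoxicity, read by MTT assay, with a stated time of 5 days; on this read-out lower numbers stand for higher toxicity in this test and higher numbers for lower toxicity in this test:
- compound 1, `Cc1cc(C)cc(S(=O)(=O)n2c(SCC(=O)Nc3ccc(C(=O)O)cc3)nc3ccccc32)c1`: 115000 nM
- compound 2, `Cc1cc(C)cc(S(=O)(=O)n2c(OCC(=O)Nc3ccccc3Br)nc3ccccc32)c1`: > 243000 nM
- compound 3, `Cc1cc(C)cc(S(=O)(=O)n2c(OCC(=O)Nc3ccccc3Cl)nc3ccccc32)c1`: 169000 nM

Compound 2 reaches only a limit of this assay, (the limit of > 243000 nM in this assay, at which 1 of the 3 values shown sits), and not a number. Of the two numbers, compound 3 and compound 1 lie within the usual scatter of each other, so no order between them can be read. Among the compounds with values here, the single measured step, an at least 1.4-fold lower number from compound 2 to compound 3 (0.15 log units; that floor lies within the scatter), has a floor that also sits within the scatter, so it tells nothing firm about the effect of the halogen swap.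

Compound 4, `COC(=O)c1ccc(NC(=O)COc2nc3ccccc3n2S(=O)(=O)c2cc(C)cc(C)c2)c(Cl)c1`, has yet to be measured. Its difference from compound 3 is methoxycarbonyl in place of hydrogen on an aromatic carbon. Within the data shown here, no measured step concerns a methoxycarbonyl group or any addition on that ring; the only step in hand, from compound 2 to compound 3, is a halogen exchange and bears on the new change only in showing that changes on the anilide ring have stayed within the scatter here. Compound 1, which carries a carboxylic acid on its anilide ring, gives a number within the scatter of compound 3. The expectation is therefore a step of a 1.2-fold lower number from compound 3 to compound 4 (0.08 log units; within the scatter) in this assay, none beyond the scatter. Compound 4 is estimated at 140000 nM, within 50000 nM to 300000 nM.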

Compound 4, half-maximal cytotoxic concentration: 119000 nM
Compound 4: the middle estimate sits 1.2-fold (0.07 log units) above what was measured, within the range that was stated.
By their numbers in this assay, from the lowest: compounds 1, 4 and 3 (each within the scatter of the next). At a limit, above all of these: compound 2.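

In this assay, the aromatic carbon para to a large group and meta to a chloro group now has a measured substitution: methoxycarbonyl in place of hydrogen gives a 1.4-fold lower number from compound 3 to compound 4 (0.15 log units; within the scatter), so no change in this read-out can be assigned to the added group. Compound 2 gives a limit of the assay and not a number: the limit of > 243000 nM in this assay, at which 1 of the 4 values shown sits. Against that limit the result is an at least 2.0-fold lower number from compound 2 to compound 4 (0.31 log units; beyond the scatter), the only listed step in this set that reaches beyond the scatter, but it joins the halogen exchange and the added methoxycarbonyl in one replacement of 2-bromophenyl by 2-chloro-4-(methoxycarbonyl)phenyl, and it gives a floor, so it cannot be assigned to either change alone.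

Still open, going by these compounds, is whether a carboxylic acid, an amine or an ethoxycarbonyl group at this same place would also stay within the scatter of compound 3 in this assay. Also open, on these data alone, is whether methoxycarbonyl at this place gives a similar step on a ring carrying bromo in place of chloro, and how far the true value of compound 2 lies from its limit.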